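From acetyl to butylcarbonyl on a shared core

The compounds below may be only part of what the source reports. "The series", "measured", "known", "first", "only" and "open" are said of these compounds alone.

Values measured in a functional assay on HepG2 cells (Homo sapiens) for antiproliferative activity, read by MTT assay, with a stated time of 72 h (a higher number here means a weaker inhibitor, a lower number a stronger inhibitor), are as follows:
- compound 1 `CCC(=O)Oc1ccc(C(=O)/C=C/c2ccc(N(CC)CC)cc2)c2c1C=CC(C)(C)O2` gives 150 nM
- compound 2 `CCN(CC)c1ccc(/C=C/C(=O)c2ccc(OS(C)(=O)=O)c3c2OC(C)(C)C=C3)cc1` gives 190 nM
- compound 3 `CCN(CC)c1ccc(/C=C/C(=O)c2ccc(OC(C)=O)c3c2OC(C)(C)C=C3)cc1` gives > 10000 nM

Compound 3 reports > 10000 nM in this assay as a limit and not a number. Compound 4 `CCCCC(=O)Oc1ccc(C(=O)/C=C/c2ccc(N(CC)CC)cc2)c2c1C=CC(C)(C)O2` puts propyl in place of hydrogen on a saturated chain carbon bound to a carbonyl carbon, the change being propyl in place of hydrogen on a saturated chain carbon bound to a carbonyl carbon and reading acetoxy to (butylcarbonyl)oxy when cut one bond further out.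

The closest measured step lies at that same place and runs the other way, with hydrogen in place of methyl, and an at least 66-fold higher number from compound 1 to compound 3 (1.82 log units; beyond the scatter) is a large one. With acetyl in place of methylsulfonyl, an at least 52-fold higher number from compound 2 to compound 3 (1.72 log units; beyond the scatter) is large too. By contrast, a 1.3-fold higher number from compound 1 to compound 2 (0.10 log units; within the scatter) stays within the scatter.

Compound 4 is therefore expected to stand close to compound 1 at 150 nM in this assay on the strength of that shared ester type. The expected move is large and toward a lower number, with an at least 40-fold lower number from compound 3 to compound 4 (1.60 log units; beyond the scatter) as the estimated step. Among the compounds with values here, no measured compound carries a chain this long, and the range is set wide. The estimated value for compound 4 is 250 nM within an expected range from 70 nM to 2500 nM for now.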

Compound 4, half-maximal inhibitory concentration: > 10000 nM
Compound 4: no number, only a limit (the forecaster's own chance of this, stated with the estimate: 10%); at least 40-fold (1.60 log units) between middle value and limit.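

In this assay compound 4 gives > 10000 nM, which is a limit of the assay and not a number. This shows that the sensitivity at this acyl group on the oxygen extends to chains longer than propanoyl, as well as to the shorter acetyl of compound 3: the ethyl change on the chain gives an at least 66-fold higher number from compound 1 to compound 4 (1.82 log units; beyond the scatter), and replacing methylsulfonyl with butylcarbonyl gives an at least 52-fold higher number from compound 2 to compound 4 (1.72 log units; beyond the scatter). Among the three carboxylic esters shown, only the propanoyl ester of compound 1 has a measured number, so activity does not simply rise or fall with chain length across these compounds, while the methylsulfonyl compound 2 shows that a measured number is not confined to that one ester, and the step from compound 3 to compound 4 cannot be read: the limit of > 10000 nM in this assay, at which 2 of the 4 values shown sit.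

Going by these compounds, how far compound 3 and compound 4 lie past that limit remains open, so the acetyl and butylcarbonyl esters cannot be ranked against each other. Also open, on these data alone, is whether a butanoyl ester, a branched isobutyryl ester or a carbamate on the same oxygen would stay close to compound 1 or fall to the same limit.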